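Trading One Five-Membered Ring for Another on a Shared Core

The compounds below may be only part of what the source reports. "The series", "measured", "known", "first", "only" and "open" are said of these compounds alone.

Two measured compounds share a core and differ only in the five-membered aromatic ring joined to it. Compound 2 `c1ccc(-c2cn[nH]c2)c(NCC2=NCCN2)c1` carries a 1H-pyrazol-4-yl group, and in an in vitro functional assay on cells (Fibroblast) for agonist activity at Alpha-1D adrenergic receptor (Homo sapiens) (a lower number here means that less compound is needed, a higher number that more compound is needed for the effect), compound 2 gives 20 nM, the lower of the two numbers in hand. Compound 1 `CCn1ncnc1-c1ccccc1NCC1=NCCN1` carries a different five-membered ring, and in this assay compound 1 gives 126 nM, a gap from compound 2 that lies beyond the usual scatter.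

Compound 3 `Cn1ccnc1-c1ccccc1NCC1=NCCN1` has not yet been measured. Relative to compound 2 the change is 1-methyl-1H-imidazol-2-yl in place of 1H-pyrazol-4-yl on an aromatic carbon. The ring that enters brings no hydrogen-bond donor, and in that respect compound 3 resembles compound 1, whose own five-membered ring likewise has none and which gives 126 nM in this assay. On that basis the step of a 3.0-fold higher number from compound 2 to compound 3 (0.48 log units; beyond the scatter) is expected to point toward a higher number, beyond the scatter but short of the distance to compound 1. For compound 3 in this assay the estimate is 60 nM, with a plausible range from 20 nM to 200 nM.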

Compound 3, half-maximal effective concentration: 200 nM
Compound 3: the middle estimate sits 3.3-fold (0.52 log units) below what was measured; the measured number falls inside the stated range.
By their numbers in this assay, from the lowest: compound 2; then compounds 1 and 3 (each within the scatter of the next).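

In this assay, putting 1-methyl-1H-imidazol-2-yl in place of 1H-pyrazol-4-yl on this aromatic carbon gives a 10-fold higher number from compound 2 to compound 3 (1.00 log units; beyond the scatter), so the two five-membered rings are far from interchangeable here. Compound 3 at 200 nM and compound 1 at 126 nM lie within the usual scatter of each other, which means that two different rings without a hydrogen-bond donor both stand well apart from compound 2, and no compound shown goes against this. Nothing measured here explains the size of the step.

From the compounds shown here alone, this swap changes the donor count, the acceptor count and the heavy-atom count all at once, so which of these matters remains open. A 1-methyl-1H-pyrazol-4-yl group or a 1H-imidazol-2-yl group without the methyl, on the same carbon, would help separate the effect of the methyl from that of the ring.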